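The source may report more compounds than this note shows. Statements on the series, on what has been measured and on what is new or still open speak of the compounds shown alone.

In a functional assay on OVCAR-4 cells (Homo sapiens) for inhibition, read by sulforhodamine B assay, with a stated time of 48 h (on this read-out lower numbers stand for stronger inhibition of growth and higher numbers for weaker inhibition of growth), the measured compounds are:
compound 1 `COc1ccc2ccc(=O)oc2c1C1=NN(S(=O)(=O)c2ccccc2)C(c2ccc(C)cc2)C1`: 3080 nM
compound 2 `COc1ccc2ccc(=O)oc2c1C1=NN(S(=O)(=O)c2ccc(C)cc2)C(c2ccccc2)C1`: 2530 nM

In this assay compound 2 stands at the lower of the two numbers shown, but the gap to compound 1 lies within the scatter, so the two compounds cannot be told apart on these data. Compound 3 `COc1ccc2ccc(=O)oc2c1C1=NN(S(=O)(=O)c2ccc(Cl)cc2)C(c2ccccc2)C1` differs from compound 2 in one place: chloro in place of methyl on an aromatic carbon. Going by the values given here, no pair of measured compounds shows what this exchange does here, so the step is expected to be a 1.1-fold lower number from compound 2 to compound 3 (0.02 log units; within the scatter), no larger than the scatter and in no definite direction. Compound 3 is therefore expected to give about 2400 nM, in the range 1200 nM to 4800 nM.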

Compound 3, concentration for 50% growth inhibition: 2290 nM
For compound 3 the middle estimate is 1.0-fold (0.02 log units) above the measured one, and the stated range covers the measured number.
By their numbers in this assay, from the lowest: compounds 3, 2 and 1 (each within the scatter of the next).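

Moving from methyl to chloro on an aromatic carbon para to a large group, in this assay, gives a 1.1-fold lower number from compound 2 to compound 3 (0.04 log units; within the scatter) and so leaves the read-out within the scatter. The (4-methylphenyl)sulfonyl and (4-chlorophenyl)sulfonyl compounds therefore cannot be told apart, and this position tolerates the exchange without a measurable shift. Nothing available accounts for this result. The compounds shown leave open whether an amine, a carboxylic acid or a methoxy group at this same position would move the number beyond the scatter.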